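The source may hold more compounds than are shown below. What is called first, only, known or untested is meant among the compounds shown, and "the series" means these compounds.

The measured compounds:
Compound 1 `Oc1ccc(CNc2cc(C(F)(F)F)cc3[nH]ncc23)cc1` gives 75% in an assay for inhibition of Tryptophan 2,3-dioxygenase (Homo sapiens), with stated times of 10 min and 60 min, tested at 10 uM; on this read-out higher numbers stand for a stronger effect at the one concentration tested and lower numbers for a weaker effect.
Compound 2 `NCCn1ncc2c(NCc3ccccc3[N+](=O)[O-])cc(C(F)(F)F)cc21` gives 25% in this assay.
Compound 3 `O=[N+]([O-])c1ccc(CNc2cc(C(F)(F)F)cc3[nH]ncc23)cc1` gives 47% in this assay.

Among these three numbers compound 2 stands lowest. Compound 3 is the nearest to it and compound 1 the furthest, and both gaps lie beyond the scatter. Among the compounds with values here, the only step measured in one place, a number 28 percentage points lower from compound 1 to compound 3 (beyond the scatter), concerns nitro in place of hydroxy on an aromatic carbon and leaves the ring nitrogen untouched. Compound 4 `CC(C)n1ncc2c(NCc3ccccc3[N+](=O)[O-])cc(C(F)(F)F)cc21` differs from compound 2 by isopropyl in place of 2-aminoethyl on an aromatic nitrogen. Within the data shown here, no measured pair isolates an exchange on that ring nitrogen, so the direction of the step has no precedent in these data; compound 3, which carries a bare ring nitrogen, also differs from compound 2 in the position of the nitro group, and its value alone cannot separate the two changes. Compound 4 is therefore expected to stay close to compound 2, with a step of a number 5 percentage points higher from compound 2 to compound 4 (within the scatter) that is not expected to clear the scatter with confidence. Compound 4 is estimated at 30%, within a range from 10% to 55%.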

Compound 4, a percentage reported as inhibition, at one concentration (the size of the read-out at that concentration, not a potency): 35%
Compound 4: the middle estimate sits 5 percentage points below what was measured, within the range that was stated.
By their numbers in this assay, from the lowest: compounds 2 and 4 (each within the scatter of the next); then compound 3; then compound 1.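

In this assay, within the data shown here, this is the first reading of an exchange on the aromatic nitrogen itself, and it gives a number 10 percentage points higher from compound 2 to compound 4 (within the scatter), so the two substituents cannot be told apart here. Both groups hold the same count of heavy atoms, yet isopropyl has neither the nitrogen nor the hydrogen-bond donor and acceptor of 2-aminoethyl, and in this pair that exchange does not move the read-out beyond the scatter. Nothing shown here accounts for this result.

The compounds shown leave open how a carboxylic acid, a longer chain or a cyclic amine on this aromatic nitrogen would read. They also leave open whether this nitrogen bearing only hydrogen would differ from compound 2 or compound 4 with the rest of the structure unchanged.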